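Fluoro in place of chloro on compound 2

This account rests on a few compounds, and the source may have more. Where it says the series, first, only, none or still open, it means among the compounds named here.

Of the compounds shown here, three sharing one core have numbers so far in a functional assay on microsomes for inhibition, with a stated time of 1 h; on this read-out higher numbers stand for weaker inhibition and lower numbers for stronger inhibition. Compound 1 (`Cn1c(NN)nc(-c2ccccc2O)c(C#N)c1=O`) gives 34 ug/mL and compound 2 (`Cn1c(NN)nc(-c2ccccc2Cl)c(C#N)c1=O`) gives 57 ug/mL while compound 3 (`CSc1nc(-c2ccccc2Cl)c(C#N)c(=O)n1C`) gives 72 ug/mL in the same measurement. Compound 2 stands within the usual scatter of repeated measurements from both of the others, so these three numbers cannot be ranked.

Compound 4 (`Cn1c(NN)nc(-c2ccccc2F)c(C#N)c1=O`) has not been measured yet. It is compound 2 with fluoro in place of chloro on an aromatic carbon, ortho to a large group.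

Two measured steps can guide an expectation. The more relevant one is at the same aromatic carbon, where chloro in place of hydroxy gave a 1.7-fold higher number from compound 1 to compound 2 (0.22 log units; within the scatter) in a swap of one group for another. The second, methylsulfanyl in place of aminoamino, lies at a different place and gave a 1.3-fold higher number from compound 2 to compound 3 (0.10 log units; within the scatter) as its result. Neither step goes beyond the scatter.

Since the swap at this same carbon gave just a 1.7-fold higher number from compound 1 to compound 2 (0.22 log units; within the scatter) there is no reason in these data to expect a step beyond the scatter in this assay for the new swap. The estimated change is a 1.1-fold lower number from compound 2 to compound 4 (0.06 log units; within the scatter) and it stays within the scatter. Compound 4 is expected near 50 ug/mL with an estimated range from 25 ug/mL to 100 ug/mL for its measured number.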

Compound 4, half-maximal inhibitory concentration: 43 ug/mL
Beside the measured number, compound 4's estimate is 1.2-fold (0.07 log units) above it, and the stated range covers the measured number.
By their numbers in this assay, from the lowest: compounds 1, 4, 2 and 3 (each within the scatter of the next, the first and the last beyond it).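

At this aromatic carbon, ortho to a large group, this assay now reads three groups on the same background: fluoro in place of chloro gives a 1.3-fold lower number from compound 2 to compound 4 (0.12 log units; within the scatter) and fluoro in place of hydroxy gives a 1.3-fold higher number from compound 1 to compound 4 (0.10 log units; within the scatter) on the same scale. Before this result, only the swap between hydroxy and chloro could be read at this carbon, whereas now all three pairs among hydroxy, chloro and fluoro can be compared, and none of the three steps goes beyond the scatter, so this read-out does not separate these groups at this position. Nothing available here explains why the number moves so little across these swaps.

The compounds shown leave open whether a different kind of group on this carbon, such as an amine, a carboxylic acid or a longer chain, would give a step beyond the scatter. They also leave open whether fluoro on this carbon would give a similar number with methylsulfanyl in place of aminoamino, the change that links compound 2 to compound 3.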